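Chalcones in a drug-resistant breast cancer cell line

This account rests on a few compounds, and the source may have more. Where it says the series, first, only, none or still open, it means among the compounds named here.

Measured so far:
compound 1, `COc1cc(OC)c(C(=O)/C=C/c2ccc(Cl)cc2)c(O)c1CC=C(C)C`: 43400 nM
compound 2, `COc1cc(O)c(C(=O)/C=C/c2ccc(N3CCNCC3)cc2)c(OC)c1`: 67500 nM
compound 3, `COc1ccc(C(=O)/C=C/c2cccc(N3CCNCC3)c2)c(OC)c1`: 95000 nM

Of the compounds shown here, three have been tested in an ADME assay on MCF7-DOX cells (Homo sapiens) for cytotoxicity, read by MTT assay, with a stated time of 48 h; on this read-out lower numbers stand for stronger inhibition and higher numbers for weaker inhibition. Compound 1 gives the lowest of the three numbers with 43400 nM. Compound 2 comes nearest to it with 67500 nM, a gap that lies within the usual scatter, so the two cannot be told apart. Compound 3 gives 95000 nM, and its gap to compound 1 lies beyond the scatter.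

Compound 4, `COc1cc(OC)c(C(=O)/C=C/c2cccc(C(F)(F)F)c2)c(O)c1CC=C(C)C`, has not yet been measured in this assay. It keeps the core of compound 1 and differs from it in one place: 3-(trifluoromethyl)phenyl in place of 4-chlorophenyl on a double-bonded chain carbon bound to a double-bonded chain carbon. Within the data shown here, no pair among the measured compounds isolates a change of this kind, so there is no measured step to lean on. For a swap of one substituted phenyl for another on the same chain carbon, the expected step from compound 1 to compound 4, a 1.1-fold lower number from compound 1 to compound 4 (0.04 log units; within the scatter), is small, with no direction that can be trusted beyond the scatter. Compound 4 is therefore expected to give about 40000 nM, with a likely range from 15000 nM to 110000 nM.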

Compound 4, half-maximal inhibitory concentration: 66600 nM
Estimate against measurement, compound 4: 1.7-fold (0.22 log units) below; low and high end bracket the measured number.
By their numbers in this assay, from the lowest: compounds 1, 4, 2 and 3 (each within the scatter of the next, the first and the last beyond it).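

In this assay, among these compounds, this is the first measured step at this place on the chain: 3-(trifluoromethyl)phenyl in place of 4-chlorophenyl gives a 1.5-fold higher number from compound 1 to compound 4 (0.19 log units; within the scatter). The core of compound 1 therefore tolerates this exchange, as the two compounds cannot be told apart even though the entering group has 10 heavy atoms against 7 in the group it replaces. No independent measurement is available to explain this result.

This single step changes both the substituent and the ring position shown in the group's name, so the effects of the two changes cannot be separated. From the compounds shown here alone, it also remains open whether a phenyl ring carrying a carboxylic acid or a nitrile at this place would move the number beyond the scatter.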